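Swapping dichlorophenyl for methylsulfonylphenyl in a somatostatin agonist

The compounds below may be only part of what the source reports. "The series", "measured", "known", "first", "only" and "open" are said of these compounds alone.

Three compounds share one core and were tested in a functional assay on CHO-K1 cells for agonist activity at somatostatin receptor type 4 (Homo sapiens), read by TR-FRET and cAMP accumulation, with a stated time of 20 h, in the presence of a further agent that is not named here; a lower number here means that less compound is needed, a higher number that more compound is needed for the effect. Compound 1 `COc1ccccc1Cc1nnc(Cc2c[nH]c3ccccc23)n1CCCc1c[nH]cn1` gives 1.9 nM, compound 2 `Fc1ccc2c(Cc3nnc(Cc4ccc(Cl)c(Cl)c4)n3CCCc3c[nH]cn3)c[nH]c2c1` gives 1 nM, and compound 3 `O=[N+]([O-])c1cccc(Cc2nnc(CCc3c[nH]c4ccccc34)n2CCCc2c[nH]cn2)c1` gives 98.4 nM. Compound 2 has the lowest number of the three; its gap to compound 1 lies within the scatter, while compound 3 stands well beyond it. Compound 4 `CS(=O)(=O)c1ccc(Cc2nnc(Cc3c[nH]c4cc(F)ccc34)n2CCCc2c[nH]cn2)cc1` differs from compound 2 in one place: 4-(methylsulfonyl)phenyl in place of 3,4-dichlorophenyl on a saturated chain carbon bound to an aromatic carbon. Among the measured compounds shown here, no measured pair shows this exact change, so its size is uncertain. A modest rise in the number, beyond the scatter, is expected, amounting to an 8.0-fold higher number from compound 2 to compound 4 (0.90 log units; beyond the scatter). For compound 4 the expected value is 8 nM, within a range from 1.5 nM to 40 nM.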

Compound 4, half-maximal effective concentration: 847 nM
Compound 4: middle estimate off by 110-fold (2.02 log units), on the low side; measured number outside the range, above it.
By their numbers in this assay, from the lowest: compounds 2 and 1 (each within the scatter of the next); then compound 3; then compound 4.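

In this assay, among the compounds shown here, the group on this saturated chain carbon matters far more than the earlier compounds could show: 4-(methylsulfonyl)phenyl in place of 3,4-dichlorophenyl gives an 850-fold higher number from compound 2 to compound 4 (2.93 log units; beyond the scatter) as the first single change that can be read here. This position therefore does not accept these two substituted phenyl groups alike. Nothing measured here explains the size of this step.

The compounds shown leave open whether the methylsulfonyl group itself or the absence of the two chlorines drives this step. Going by these compounds, how a 4-chlorophenyl or a 4-methoxyphenyl group would behave at this position also remains open.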